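Swapping Chloro for Bromo on Compound 1

The compounds below may be only part of what the source reports. "The series", "measured", "known", "first", "only" and "open" are said of these compounds alone.

- Compound 1 (`NC1=NC2(CCOCC2)N(OCCCOc2ccccc2Cl)C(N)=N1`): 660 nM
- Compound 2 (`NC1=NC2(CCSCC2)N(OCCCOc2cccc(Cl)c2Cl)C(N)=N1`): 30 nM

Both compounds were tested in a functional assay on HL-60 cells (Homo sapiens) for antiproliferative activity, read by MTT assay, with a stated time of 72 h; a higher number here means a weaker inhibitor, a lower number a stronger inhibitor. Compound 1 stands at the top of this short scale with 660 nM, making it the weaker inhibitor of the pair. Compound 2 reads 30 nM, a gap well beyond the usual scatter. The two compounds differ in more than one place, however, so the gap cannot be tied to any single change.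

The next compound to be measured, compound 3 (`NC1=NC2(CCOCC2)N(OCCCOc2ccccc2Br)C(N)=N1`), keeps the core of compound 1 and changes one substituent. The 2-chlorophenoxy group becomes 2-bromophenoxy, with bromo in place of chloro on an aromatic carbon, ortho to a large group: bromo in place of chloro on an aromatic carbon.

For the measured compounds named here, no measured pair shows this exchange, so the expectation rests on the modest structural change alone. No step beyond the scatter is expected in this assay, with only a slight lean towards a lower number. The estimated change is a 1.4-fold lower number from compound 1 to compound 3 (0.14 log units; within the scatter). For compound 3 the estimated value is 480 nM, with an expected range of 190 nM to 1200 nM.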

Compound 3, half-maximal inhibitory concentration: 610 nM
The estimate for compound 3 lay 1.3-fold (0.10 log units) below the measured number; the measured number falls inside the stated range.
By their numbers in this assay, from the lowest: compound 2; then compounds 3 and 1 (each within the scatter of the next).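

In this assay, for the compounds shown here, the exchange of chloro for bromo, on an aromatic carbon ortho to a large group, gives a 1.1-fold lower number from compound 1 to compound 3 (0.03 log units; within the scatter) and is the only step here that alters a single place. It shows that, on the core of compound 1, this position accepts either of these two halogens without a difference that can be told from the scatter, so the 2-chlorophenoxy and 2-bromophenoxy groups cannot be separated by this read-out. No measurement is at hand that would explain why the two behave alike in this assay.

The compounds shown leave open whether this insensitivity belongs to the position or only to this pair of halogens, since a fluoro, methyl, methoxy or nitrile group at the same place, or a bare hydrogen there, could read quite differently. They also leave open whether the same exchange would give a similar result on another core, and what a second substituent on the phenoxy ring, or a shorter or longer chain to it, would do on the core of compound 1.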